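The source may report more compounds than this note shows. Statements on the series, on what has been measured and on what is new or still open speak of the compounds shown alone.

Measured so far:
- compound 1 `O=C(CCCCC1CCSS1)Nc1ccccc1Cl`: 3.38%
- compound 2 `O=C(CCCCC(S)CCS)Nc1ccccc1`: 25.4%

In a functional assay on NCI-H460 cells (Homo sapiens) for inhibition, read by MTT assay, with a stated time of 24 h, tested at 100 ug/mL (on this read-out higher numbers stand for more inhibition of growth at the one concentration tested and lower numbers for less inhibition of growth), compound 2 gives 25.4% and so holds the higher of the two numbers. Compound 1 gives 3.38% in the same test, and this gap lies beyond the usual scatter. The next compound to be tested is compound 3 `O=C(CCCCC(S)CCS)Nc1ccccc1Cl`, which is built from compound 2 by one small edit: chloro in place of hydrogen on an aromatic carbon. In words, this is chloro in place of hydrogen on an aromatic carbon, ortho to a large group. Among the measured compounds shown here, no measured pair of compounds shows this edit alone, so the data give no direct guide to its size. The working expectation in this assay is therefore no shift beyond the scatter, in either direction. The expected step is a number 2.4 percentage points lower from compound 2 to compound 3 (within the scatter) and it carries wide uncertainty. Compound 3 is estimated at 23% within an expected range of 8% to 42%.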

Compound 3, percent growth inhibition at one concentration: 12.1%
For compound 3 the middle estimate is 10.9 percentage points above the measured one, and the stated range covers the measured number.
By their numbers in this assay, from the lowest: compounds 1 and 3 (each within the scatter of the next); then compound 2.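

In this assay, among the compounds shown here, the first single change with a readable effect is chloro in place of hydrogen on an aromatic carbon, ortho to a large group, which gives a number 13.3 percentage points lower from compound 2 to compound 3 (beyond the scatter) on the open-chain compounds. So this position is not indifferent to the change, and here the chloro goes with less inhibition of growth. With the chloro kept, the open chain with two sulfur atoms in place of the five-membered ring gives a number 8.7 percentage points higher from compound 1 to compound 3 (within the scatter) and so shows no clear effect, and nothing at hand explains either step.

One chloro at one place says little about other groups there, such as a methoxy or a fluoro. On these data alone, whether the same step would hold with the chloro elsewhere on the ring, or with a longer chain, remains open.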